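Trading one aryl for another on the amide side chain

This account rests on a few compounds, and the source may have more. Where it says the series, first, only, none or still open, it means among the compounds named here.

Of the compounds shown here, three sharing one core have been tested in a functional assay on A2780 cells (Homo sapiens) for antiproliferative activity, read by resazurin assay, with a stated time of 72 h; a lower number here means a stronger inhibitor, a higher number a weaker inhibitor. Compound 1 `CCCN(C)C(=O)c1cc2c(Cc3ccccc3)n[nH]c2cc1O` carries a propyl chain on the amide nitrogen; in this assay compound 1 gives > 10000 nM, which is a limit of the assay rather than a number (the limit of > 10000 nM in this assay, at which 1 of the 3 values shown sits). Compound 2 `CN(Cc1cccc(F)c1)C(=O)c1cc2c(Cc3ccccc3)n[nH]c2cc1O` puts a 3-fluorophenyl on a saturated chain carbon bound to the amide-type nitrogen and gives 5000 nM in this assay. Compound 3 `Cc1ccc(CN(C)C(=O)c2cc3c(Cc4ccccc4)n[nH]c3cc2O)cc1` carries a 4-methylphenyl at the same place and gives 6900 nM in this assay. Compound 2 therefore holds the lowest of the two numbers, with compound 3 separated from it by a 1.4-fold higher number from compound 2 to compound 3 (0.14 log units; within the scatter). Against compound 1 the steps are an at least 2.0-fold lower number from compound 1 to compound 2 (0.30 log units; that floor lies within the scatter) and an at least 1.4-fold lower number from compound 1 to compound 3 (0.16 log units; that floor lies within the scatter).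

Compound 4 `COc1cccc(CN(C)C(=O)c2cc3c(Cc4ccccc4)n[nH]c3cc2O)c1OC` is not yet measured. It differs from compound 2 by 2,3-dimethoxyphenyl in place of 3-fluorophenyl on a saturated chain carbon bound to an amide-type nitrogen. Among the compounds with values here, the one measured step among aryl-bearing analogues, a 1.4-fold higher number from compound 2 to compound 3 (0.14 log units; within the scatter), shows that exchanging one substituted phenyl for another left the number essentially unchanged, so no step beyond the scatter is expected here either. For compound 4 the expected step is a 1.2-fold higher number from compound 2 to compound 4 (0.08 log units; within the scatter). In this assay compound 4 is estimated at 6000 nM, within a range of 2500 nM to 15000 nM.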

Compound 4, half-maximal inhibitory concentration: 4800 nM
Compound 4: middle estimate off by 1.3-fold (0.10 log units), on the high side; measured number inside the range.
By their numbers in this assay, from the lowest: compounds 4, 2 and 3 (each within the scatter of the next). At a limit, above all of these: compound 1.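

On a saturated chain carbon bound to an amide-type nitrogen, 2,3-dimethoxyphenyl has more heavy atoms than 3-fluorophenyl and, unlike it, has hydrogen-bond acceptors, yet no difference could be told apart in this assay: the readings are a 1.0-fold lower number from compound 2 to compound 4 (0.02 log units; within the scatter) and a 1.4-fold lower number from compound 3 to compound 4 (0.16 log units; within the scatter), so three differently substituted phenyl groups now sit within the scatter of one another. Within the data shown here, the comparison with the ethyl-ending chain also sharpens, as the step of an at least 2.0-fold lower number from compound 1 to compound 4 (0.31 log units; beyond the scatter) is the first from that compound whose floor lies beyond the scatter, giving at least a modest gain for an aryl group at this place. Compound 1 stands at a limit of the assay and not at a number: the limit of > 10000 nM in this assay, at which 1 of the 4 values shown sits.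

The compounds shown leave open whether an unsubstituted phenyl, a basic amine or a carboxylic acid at this place would move the number beyond the scatter of these aryl analogues. They also leave open how large the true gap to compound 1 is, as only a floor for it can be read.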